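A few compounds are considered here, and "the series" means these few. Any claim that something is new, unique, unknown or untested is made for them only; others in the source may bear on it.

Measured so far:
- compound 1, `COc1ccc(OC)c(/C=C/c2nnc(Nc3ccc(Cl)cc3)o2)c1`, a functional assay on MOLT-4 cells (Homo sapiens) for antiproliferative activity, read by sulforhodamine B assay, with a stated time of 48 h; a higher number here means a weaker inhibitor of growth, a lower number a stronger inhibitor of growth: > 100000 nM
- compound 2, `COc1ccc(OC)c(/C=C/C(=O)N/N=C/c2ccc(Cl)cc2)c1`; in this assay compound 2 gives 523 nM.

The value of compound 1 is a limit of the assay, not a number; it is the only such entry here, (the limit of > 100000 nM in this assay, at which 1 of the 2 values shown sits). Among the compounds with values here, compound 2 is the one compound of the pair with a numerical result in this assay, and it gives 523 nM there. Within the data shown here, no step between measured compounds is given, and the two compounds differ in more than one place, so their two results are stated side by side and nothing more is drawn from the pair.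

The next compound, compound 3, `COc1ccc(OC)c(/C=C/C(=O)N/N=C/c2ccccc2)c1`, is compound 2 with hydrogen in place of chloro on an aromatic carbon, the same difference cut one bond further out reading as 4-chlorophenyl to phenyl. Among the measured compounds shown here, no measured step informs this change. The expectation is a step of modest size, tending towards weaker inhibition of growth, but one that may well sit within the scatter of repeated measurements. The estimated step of a 1.7-fold higher number from compound 2 to compound 3 (0.24 log units; within the scatter) is set accordingly. Compound 3 is expected to give about 900 nM in this assay, in the range 250 nM to 3500 nM.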

Compound 3, concentration for 50% growth inhibition: 4450 nM
Compound 3: the middle estimate sits 4.9-fold (0.69 log units) below what was measured, and the stated range ends below it.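

Working notes on the series: in this assay the change from 4-chlorophenyl to phenyl gives an 8.5-fold higher number from compound 2 to compound 3 (0.93 log units; beyond the scatter) and is the first step in the series that can be read across a single difference. It shows that this place on the aromatic ring, para to a large group, is not indifferent to what it carries: of this pair, the compound with chloro there is the stronger inhibitor of growth, and the step lies beyond the scatter. Nothing shown here bears on why the loss of this one chlorine atom gives a step of this size.

As far as these compounds go, whether the step is particular to chloro or would also appear with fluoro, bromo, methyl or methoxy at the same place remains open, and with only hydrogen and chloro compared, no ordering of substituents can be drawn. Also open, from the compounds shown here alone, is whether the same change would give a step of similar size at another place on this ring or on a different core, since the reading rests on one pair in one assay.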